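Lengthening the chloroalkyl chain: from a limit toward compound 4

The compounds below may be only part of what the source reports. "The series", "measured", "known", "first", "only" and "open" are said of these compounds alone.

In a functional assay on MCF7 cells (Homo sapiens) for antiproliferative activity, with a stated time of 48 h (on this read-out lower numbers stand for stronger inhibition and higher numbers for weaker inhibition), compound 1 `CC(C)(C)c1ccc(NC(=O)CCl)cc1` gives 5400 nM. Compound 2 `CC(C)(C)c1ccc(NC(=O)CCCl)cc1`, whose chain is longer by one carbon, gives 49000 nM in this assay. Among the compounds with values here, that single step, a 9.1-fold higher number from compound 1 to compound 2 (0.96 log units; beyond the scatter), is the only measured comparison between two numbers here. Compound 3 `O=C(CCCCl)Nc1ccc(I)cc1` carries the longest chain and an iodo group on the ring. In this assay compound 3 gives > 100000 nM, which is a limit of the assay and not a number. Compound 3 therefore stands at the limit of > 100000 nM in this assay, at which 1 of the 3 values shown sits, with no numerical value of its own, while compounds 1 and 2 have measured numbers.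

Compound 4 `CC(C)(C)c1ccc(NC(=O)CCCCl)cc1` differs from compound 3 in one place: tert-butyl in place of iodo on an aromatic carbon. Within the data shown here, no measured step bears directly on swapping iodo for tert-butyl on the ring, since the one measured step concerns the chain. Compound 4 keeps the longest chain of compound 3, and the measured step from compound 1 to compound 2 already pointed toward weaker inhibition as that chain grew. The step of a number no higher from compound 3 to compound 4 (the limit leaves the size open) is therefore expected to stay small, and compound 4 is expected to give about 100000 nM in this assay, with a range from 30000 nM to 300000 nM, quite possibly reported only as a limit.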

Compound 4, half-maximal inhibitory concentration: > 100000 nM
Compound 4 ended at the assay's limit; the forecaster's own chance of this, stated with the estimate: 50%; the middle value sits exactly at the limit.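

With tert-butyl kept on the ring, this assay now shows an at least 18-fold higher number from compound 1 to compound 4 (1.26 log units; beyond the scatter) and so the longest chain of this set stands clearly apart from the shortest. The last added carbon is harder to judge: the data give an at least 2.0-fold higher number from compound 2 to compound 4 (0.30 log units; that floor lies within the scatter) and a floor of that size cannot by itself show a real change beyond compound 2. The value of compound 4 is a limit of the assay and not a number, and with compound 3 also ending at a limit, the swap of iodo for tert-butyl on this chain cannot be read, so this chain length gives no view of what the ring group does, and the data here stop at the assay's ceiling: the limit of > 100000 nM in this assay, at which 2 of the 4 values shown sit.

As far as these compounds go, how far past that limit compound 3 and compound 4 lie stays open, and so does whether iodo would behave like tert-butyl on the shorter chains of compound 1 and compound 2. Also open, from the compounds shown here alone, is what a bromo group or an amine would do in place of the chloro group at the end of the chain.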